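The source may hold more compounds than are shown below. What is called first, only, known or untested is meant among the compounds shown, and "the series" means these compounds.

Measured compounds in a functional assay, read by spectrophotometry, with a stated time of 30 min; a higher number here means a weaker inhibitor, a lower number a stronger inhibitor:

Compound 1 `Cc1nc2c3ccccc3ccc2c2nc3c(ccc4ccccc43)c(-c3ccccc3Cl)c12` gives 118 ug/mL in this assay.
Compound 2 `Cc1nc2c3ccccc3ccc2c2nc3c(ccc4ccccc43)c(C)c12` gives 129 ug/mL in this assay.
Compound 3 `Cc1nc2c3ccccc3ccc2c2nc3c(ccc4ccccc43)c(-c3cccc4ccccc34)c12` gives 111 ug/mL in this assay.

Compound 3 carries the smallest of the three numbers, but neither gap separates it from the others: a 1.1-fold lower number from compound 1 to compound 3 (0.03 log units; within the scatter) and a 1.2-fold lower number from compound 2 to compound 3 (0.07 log units; within the scatter) are both within the scatter, so the three measured compounds read as one level in this assay.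

The next compound, compound 4 `COc1ccc(-c2c3ccc4ccccc4c3nc3c2c(C)nc2c4ccccc4ccc32)cc1`, differs from compound 3 at a single place: 4-methoxyphenyl in place of naphthalen-1-yl on an aromatic carbon

All three measured steps bear on this same position, since methyl, 2-chlorophenyl and naphthalen-1-yl have each sat there: a 1.1-fold higher number from compound 1 to compound 2 (0.04 log units; within the scatter), a 1.1-fold lower number from compound 1 to compound 3 (0.03 log units; within the scatter) and a 1.2-fold lower number from compound 2 to compound 3 (0.07 log units; within the scatter). None of them moved the number beyond the scatter, whether the group was small or large. Within the data shown here, no measured compound carries 4-methoxyphenyl or any hydrogen-bond acceptor at this position, so that part of the change has no precedent. On the evidence of the three steps, no step beyond the scatter is expected in this assay; the estimated step is a 1.0-fold higher number from compound 3 to compound 4 (0.02 log units; within the scatter). Compound 4 is therefore expected to give 115 ug/mL in this assay, with a range from 70 ug/mL to 190 ug/mL.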

Compound 4, half-maximal inhibitory concentration: 133 ug/mL
Compound 4: middle estimate off by 1.2-fold (0.06 log units), on the low side, and the stated range covers the measured number.
By their numbers in this assay, from the lowest: compounds 3, 1, 2 and 4 (each within the scatter of the next).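

Compound 4 puts the first hydrogen-bond acceptor and the first oxygen of the series on this aromatic carbon opposite the ring nitrogen, yet in this assay the exchange of naphthalen-1-yl for 4-methoxyphenyl does not separate the two compounds (a 1.2-fold higher number from compound 3 to compound 4 (0.08 log units; within the scatter)). The same holds against the other two groups that have sat at this carbon, with methyl giving way to 4-methoxyphenyl (a 1.0-fold higher number from compound 2 to compound 4 (0.01 log units; within the scatter)) and 2-chlorophenyl giving way to it (a 1.1-fold higher number from compound 1 to compound 4 (0.05 log units; within the scatter)), so all four compounds now read as one level. The flat picture therefore extends from carbon-only groups to one carrying an oxygen, and no supporting data bear on why the number stays level.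

Still open, going by these compounds, is whether a carboxylic acid, a primary amine or a longer alkyl chain on this carbon would break away from that level in this assay. Every step shown sits at this one carbon, which leaves open whether replacing the methyl group elsewhere on the shared core, for example with an ethyl group, would move the number at all.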